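A few compounds are considered here, and "the series" means these few. Any claim that something is new, unique, unknown or untested is made for them only; others in the source may bear on it.

Compound 1 `CCOC(=O)C1=C(Nc2ccccc2)S/C(=C\c2ccccc2)C1=O` is the starting point. In a functional assay on K562 cells (Homo sapiens) for inhibition, read by MTT assay, with a stated time of 72 h, tested at 10 uM (on this read-out lower numbers stand for less inhibition and higher numbers for more inhibition at the one concentration tested (going by the name of the read-out)), compound 1 gives 42.9%, the highest of the three measured numbers. Compound 2 `CCOC(=O)C1=C(Nc2ccccc2)S/C(=C\c2ccc(OC)cc2)C1=O` gives 9.6%, and compound 3 `CCOC(=O)C1=C(Nc2ccccc2)S/C(=C\c2ccc(C(=O)O)cc2)C1=O` gives 27.5%. Both measured steps put a group onto the same ring: a number 33.3 percentage points lower from compound 1 to compound 2 (beyond the scatter) and a number 15.4 percentage points lower from compound 1 to compound 3 (beyond the scatter), each lowering inhibition beyond the scatter. Compound 4 `CCOC(=O)C1=C(Nc2ccccc2)S/C(=C\c2ccccc2C(F)(F)F)C1=O` differs from compound 1 by trifluoromethyl in place of hydrogen on an aromatic carbon. For the measured compounds named here, no measured step carries this group or this place, so the two ring-substitution steps are the only guide, and both point downward. A modest drop is therefore expected, as a number 14.9 percentage points lower from compound 1 to compound 4 (beyond the scatter), though a smaller or larger one cannot be ruled out. Compound 4 is estimated at 28%, between 8% and 50%.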

Compound 4, a percentage reported as inhibition, at one concentration (the size of the read-out at that concentration, not a potency): 19.7%
The estimate for compound 4 lay 8.3 percentage points above the measured number; the range from low to high includes it.
By their numbers in this assay, from the lowest: compound 2; then compounds 4 and 3 (each within the scatter of the next); then compound 1.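

In this assay, trifluoromethyl in place of hydrogen, here on an aromatic carbon ortho to a large group, gives a number 23.2 percentage points lower from compound 1 to compound 4 (beyond the scatter). This extends the earlier picture to a third group and a new place: all three groups on this ring give less inhibition than hydrogen does in compound 1, and no compound shown goes against that. Nothing available explains this drop. On these data alone, whether a smaller group such as fluorine or an amine at this place would retain the inhibition of compound 1 stays open. So does whether trifluoromethyl at another place on the ring would lower it as much.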